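Fluoro for propyl on the urea aryl ring

This account rests on a few compounds, and the source may have more. Where it says the series, first, only, none or still open, it means among the compounds named here.

Within the data shown here, compound 3 `CCCc1ccc(NC(=O)N[C@@H](C)c2ccccc2)cc1` stands second highest of the three numbers so far in an ADME assay on the whole organism with Oryza sativa as the target, tested at 10 uM (on this read-out higher numbers stand for a weaker effect at the one concentration tested and lower numbers for a stronger effect), where compound 3 gives 73%. Its nearest neighbour is compound 1 `CCc1cccc(NC(=O)N[C@@H](C)c2ccccc2)c1`, which in this assay gives 86%; compound 1 differs from compound 3 in more than one place, so the two values are simply reported side by side. The furthest is compound 2 `CCCc1ccc(NC(=O)N[C@H](C)c2ccccc2)cc1`, which in this assay gives 35%. Among the measured compounds shown here, the one measured step, a number 38 percentage points higher from compound 2 to compound 3 (beyond the scatter), rests on the fact that compounds 2 and 3 differ only in the configuration as drawn and says nothing about the aromatic substituent. Compound 4 `C[C@H](NC(=O)Nc1ccc(F)cc1)c1ccccc1` differs from compound 3 by fluoro in place of propyl on an aromatic carbon. For the measured compounds named here, no measured step covers this exchange, so the step expected in this assay is one of uncertain direction, most likely not beyond the scatter. For compound 4 the estimate in this assay is 75%, within 45% to 98%. The expected change is thus a number 2 percentage points higher from compound 3 to compound 4 (within the scatter).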

Compound 4, a percentage reported as activity, at one concentration (the size of the read-out at that concentration, not a potency): 85%
The estimate for compound 4 lay 10 percentage points below the measured number; the range from low to high includes it.
By their numbers in this assay, from the lowest: compound 2; then compound 3; then compounds 4 and 1 (each within the scatter of the next).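

Replacing propyl with fluoro on an aromatic carbon, para to a large group, gives in this assay a number 12 percentage points higher from compound 3 to compound 4 (beyond the scatter). Among these compounds, the only step measured before this one concerned configuration, so this is the first sign that the aromatic substituent at this position also moves the read-out. With the stereocentre held as drawn in compound 3, the change from propyl to fluoro goes with a weaker effect at the one concentration tested. Nothing at hand explains why this exchange gives a step of this size.

The compounds shown leave open how a chloro group, a methyl group or a longer chain such as butyl would read at this position. They also leave open whether fluoro in place of propyl would give a similar step on the configuration drawn in compound 2.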